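Amide to acid on the ethenyl chain

The source may report more compounds than this note shows. Statements on the series, on what has been measured and on what is new or still open speak of the compounds shown alone.

Compound 3 (`C[C@H](Oc1ccc2ncc(/C=C/C(N)=O)c(C3CC3)c2c1)c1c(Cl)ccc(F)c1Cl`) gives > 5.5 in a physicochemical assay for lipophilicity, using the shake flask method (on this read-out higher numbers stand for higher lipophilicity and lower numbers for lower lipophilicity), as a limit of the assay and not a number. Within the data shown here, compound 3 is the only compound at the limit of > 5.5 in this assay, at which 1 of the 3 values shown sits. The change to compound 4 (`C[C@H](Oc1ccc2ncc(/C=C/C(=O)O)c(C3CC3)c2c1)c1c(Cl)ccc(F)c1Cl`) puts hydroxy in place of amino on a carbonyl carbon. Among the measured compounds shown here, compound 1 (`C[C@H](Oc1ccc2ncc(/C=C/c3nn[nH]n3)c(C3CC3)c2c1)c1c(Cl)ccc(F)c1Cl`) gives 3.7 in this assay and the one measured step on this chain is a number at least 1.80 log units higher from compound 1 to compound 3 (beyond the scatter) with carbamoyl in place of 2H-tetrazol-5-yl. Compound 2 (`C[C@H](Oc1ccc2ncc(/C=C/C(=O)O)c(C3CC3)c2c1)c1c(Cl)ccc(N)c1Cl`) also carries 2-carboxyethenyl and gives 2.8 in this assay as the closest guide. A large downward step is therefore expected, estimated as a number at least 2.00 log units lower from compound 3 to compound 4 (beyond the scatter) in size. For compound 4 the estimate is 3.5 (expected range 2.9 to 4.2).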

Compound 4, distribution coefficient: 4.1
Beside the measured number, compound 4's estimate is 0.60 log units below it, and the stated range covers the measured number.
By their numbers in this assay, from the lowest: compound 2; then compound 1; then compound 4. At a limit, above all of these: compound 3.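

In this assay compound 3 holds a limit and not a number: the limit of > 5.5 in this assay, at which 1 of the 4 values shown sits.

Hydroxy in place of amino on a carbonyl carbon gives a number at least 1.40 log units lower from compound 3 to compound 4 (beyond the scatter), a step with a limit at one end. With carboxy kept, fluoro in place of amino on an aromatic carbon gives a number 1.30 log units higher from compound 2 to compound 4 (beyond the scatter), and on the same chain carbon carboxy in place of 2H-tetrazol-5-yl gives a number 0.40 log units higher from compound 1 to compound 4 (beyond the scatter).

On these data alone, the full size of the step from the carbamoyl group stays open. So does the read-out for a methyl ester or a sulfonamide at this position.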